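The compounds below may be only part of what the source reports. "The series", "measured", "known", "first", "only" and "open" are said of these compounds alone.

Measured compounds:
Compound 1 `CCOC(=O)CCCCCOc1cccc(CN(C(=O)c2ccc(-c3ccncc3)cc2)C(C)C)c1` gives in an ADME assay on HepG2 cells (Homo sapiens) for cytotoxicity, read by CellTiter-Glo and resazurin assay, with a stated time of 72 h (on this read-out lower numbers stand for an effect already at smaller amounts and higher numbers for an effect only at larger amounts of compound), a value of > 26000 nM, which is a limit of the assay and not a number.
Compound 2 `CCOC(=O)CCCCCOc1cccc(CN(C(=O)c2ccc(-c3cccnc3)cc2)C(C)C)c1` gives in this assay a value of > 26000 nM, again a limit.
Compound 3 `CCOC(=O)CCCCCOc1cccc(CN(C(=O)c2ccc(-c3cccc(OCC(C)C)c3)cc2)C(C)C)c1` gives in this assay a value of > 26000 nM, also a limit.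

Compound 3 therefore stands where every value shown stands, at the limit of > 26000 nM in this assay, at which 3 of the 3 values shown sit; none of the three compounds can be placed in order. The steps a step that the two limits leave unreadable from compound 1 to compound 2, a step that the two limits leave unreadable from compound 1 to compound 3 and a step that the two limits leave unreadable from compound 2 to compound 3 are accordingly not readable in size or direction.

Compound 4 `CCOC(=O)CCCCCOc1cccc(CN(C(=O)c2ccc(-c3ccoc3)cc2)C(C)C)c1` differs from compound 3 by furan-3-yl in place of 3-(isobutoxy)phenyl on an aromatic carbon. For the measured compounds named here, no measured step bears readably on this change, so no step beyond the scatter can be expected from it. For compound 4 the expected outcome in this assay is an estimate of 30000 nM, ranging from 8000 nM to 100000 nM, with the implied step that the limit leaves unreadable from compound 3 to compound 4 being an expectation only.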

Compound 4, half-maximal effective concentration: > 26000 nM
Compound 4: only a limit was reported; the forecaster's own chance of this, stated with the estimate: 85%; the middle value is on the limit's open side.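

In this assay compound 4 gives > 26000 nM, again a limit, so its steps from compound 1, compound 2 and compound 3 cannot be read. The compounds shown leave open whether these four aromatic groups differ at all in this assay: the limit of > 26000 nM in this assay, at which 4 of the 4 values shown sit.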